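From Pyridin-2-yl to 4-Methylphenyl on the Five-Membered Ring

The source may report more compounds than this note shows. Statements on the series, on what has been measured and on what is new or still open speak of the compounds shown alone.

Compound 1, `C=C1C(=O)[C@]23C[C@@]1(O)CC[C@H]2c1ccc(OS(=O)(=O)c2ccc(C)cc2)c(C)c1[C@@H]3Cn1cc(-c2ccccn2)nn1`, gives 2310 nM in a functional assay on A549 cells (Homo sapiens) for cytotoxicity, read by MTT assay, with a stated time of 4 days; on this read-out lower numbers stand for stronger inhibition and higher numbers for weaker inhibition.
Compound 2, `Cc1ccc(S(=O)(=O)Oc2ccc3c(c2C)[C@H](Cn2cc(-c4ccccn4)nn2)[C@@]24CC(=O)[C@@](C)(CC[C@@H]32)C4)cc1`, gives only a limit of this assay, namely > 20000 nM.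
Compound 3, `C=C1C(=O)[C@]23C[C@@]1(O)CC[C@H]2c1ccc(O)c(C)c1[C@@H]3Cn1cc(-c2ccccn2)nn1`, gives 1570 nM in this assay.

Compound 3 thus holds the lowest of the two real numbers, though its gap to compound 1 is small: a 1.5-fold lower number from compound 1 to compound 3 (0.17 log units; within the scatter). Within the data shown here, that is the only measured step, and it concerns the sulfonyl on the oxygen, not the five-membered ring.

Compound 4, `C=C1C(=O)[C@]23C[C@@]1(O)CC[C@H]2c1ccc(O)c(C)c1[C@@H]3Cn1cc(-c2ccc(C)cc2)nn1`, differs from compound 3 by 4-methylphenyl in place of pyridin-2-yl on an aromatic carbon. Among the measured compounds shown here, no measured step touches this position, so nothing here points to a change beyond the scatter in either direction in this assay.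

Compound 4 is therefore expected to give about 1600 nM in this assay, plausibly between 500 nM and 6000 nM. The expected step is a 1.0-fold higher number from compound 3 to compound 4 (0.01 log units; within the scatter).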

Compound 4, half-maximal inhibitory concentration: 1260 nM
For compound 4 the middle estimate is 1.3-fold (0.10 log units) above the measured one; the measured number falls inside the stated range.
By their numbers in this assay, from the lowest: compounds 4, 3 and 1 (each within the scatter of the next). At a limit, above all of these: compound 2.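

Among these compounds, this is the first measured step at this position on the five-membered ring, and exchanging pyridin-2-yl for 4-methylphenyl in this assay gives a 1.2-fold lower number from compound 3 to compound 4 (0.10 log units; within the scatter). The ring nitrogen of pyridin-2-yl, with its hydrogen-bond acceptor, can therefore be lost in this pair without a change beyond the scatter. No measurement shown speaks to the reason for this result. Still open, as far as these compounds go, is how this position responds to groups of another kind, such as a carboxylic acid, an amine or a longer chain in place of the aromatic ring.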